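The source may hold more compounds than are shown below. What is called first, only, known or untested is meant among the compounds shown, and "the series" means these compounds.

Measured so far in an assay on isolated protein for inhibition of leukotriene B4 receptor 1 (Homo sapiens), tested at 10 uM; a higher number here means more inhibition at the concentration tested (going by the name of the read-out), a lower number less inhibition:
compound 1 `CCc1cc(C(C)=O)c(O)cc1OCCCC(C)(C)C#N` gives 85%
compound 2 `CCc1cc(C(C)=O)c(O)cc1OCCCCCCS(C)(=O)=O` gives 99%

Compound 2 stands highest of the two numbers; its nearest neighbour is compound 1, and the step of a number 14 percentage points higher from compound 1 to compound 2 (beyond the scatter) lies beyond the usual scatter of this assay. The two differ only at the end of the chain on the oxygen of the shared core, where 3-(methylsulfonyl)propyl replaces 1-cyano-1-methylethyl.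

The next compound, compound 3 `CCc1cc(C(C)=O)c(O)cc1OCCCCCCc1nnn[nH]1`, keeps the whole of compound 2 except at the far end of that chain: 1H-tetrazol-5-yl in place of methylsulfonyl on a saturated chain carbon, six bonds along the chain from an oxygen on an aromatic ring

Among the compounds with values here, only the one measured step touches this chain end, and it shows that exchanging the group there moved the inhibition by a modest amount, in the direction of compound 2. Within the data shown here, no step involving 1H-tetrazol-5-yl has been measured, so the expectation for compound 3 rests on compound 2 sitting near the top of the scale. The inhibition of compound 3 is therefore expected to stay high, with a step of a number 5 percentage points lower from compound 2 to compound 3 (within the scatter) that lies within the scatter. The estimate for compound 3 is 94%, with a range from 78% to 100%.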

Compound 3, a percentage reported as inhibition, at one concentration (the size of the read-out at that concentration, not a potency): 91%
Beside the measured number, compound 3's estimate is 3 percentage points above it; low and high end bracket the measured number.
By their numbers in this assay, from the lowest: compounds 1, 3 and 2 (each within the scatter of the next, the first and the last beyond it).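

In this assay, the far end of this chain accepts a very different group: putting 1H-tetrazol-5-yl, a five-membered aromatic ring with 4 hetero atoms, in place of the open-chain methylsulfonyl gives a number 8 percentage points lower from compound 2 to compound 3 (within the scatter) and so no real change, which means that inhibition at this concentration does not depend on methylsulfonyl itself. The tetrazole also fails to separate from the shorter branched nitrile end, with a number 6 percentage points higher from compound 1 to compound 3 (within the scatter), although the earlier step of a number 14 percentage points higher from compound 1 to compound 2 (beyond the scatter) did lie beyond the scatter, so the three compounds form a continuous high group in which only the two outer ones can be told apart. No measurement at hand bears on why such different end groups read alike.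

On these data alone, whether a carboxylic acid or an amine at the end of the chain would hold inhibition this high remains open, as does the effect of a shorter or longer chain carrying the tetrazole. All of these readings come from a single concentration near the top of the scale, so how the potencies of these compounds compare also stays open.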